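From 4-hydroxy-2-methylphenyl to 4-ethylphenyl

The compounds below may be only part of what the source reports. "The series", "measured", "known", "first", "only" and "open" are said of these compounds alone.

In a functional assay on HOP-92 cells (Homo sapiens) for inhibition, read by sulforhodamine B assay, with a stated time of 48 h (a higher number here means a weaker inhibitor of growth, a lower number a stronger inhibitor of growth), compound 1 `Cc1ccc(C2=NN(c3ccc(S(C)(=O)=O)cc3)C(=O)CC2)cc1` gives 420 nM, while compound 2 `Cc1cc(O)ccc1C1=NN(c2ccc(S(C)(=O)=O)cc2)C(=O)CC1` gives 6490 nM. Compound 2 thus holds the higher of the two numbers, which makes it the weaker growth inhibitor of this pair. Compound 3 `CCc1ccc(C2=NN(c3ccc(S(C)(=O)=O)cc3)C(=O)CC2)cc1` keeps the shared core but has 4-ethylphenyl in place of 4-hydroxy-2-methylphenyl on a carbon with a double bond to nitrogen. Among the compounds with values here, one measured step bears on this change. It is a 15-fold higher number from compound 1 to compound 2 (1.19 log units; beyond the scatter), a large step beyond the scatter, which came with 4-hydroxy-2-methylphenyl in place of 4-methylphenyl on that same carbon. Like the 4-methylphenyl of compound 1, the 4-ethylphenyl of compound 3 carries no hydroxy group, although no measured compound shows what ethyl in place of methyl does. A large step to a lower number is therefore expected in this assay, landing near the value of compound 1. The expected change is a 13-fold lower number from compound 2 to compound 3 (1.11 log units; beyond the scatter). For compound 3 the estimated value is 500 nM, with an expected range of 150 nM to 1700 nM.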

Compound 3, concentration for 50% growth inhibition: 1580 nM
Beside the measured number, compound 3's estimate is 3.2-fold (0.50 log units) below it, within the range that was stated.
By their numbers in this assay, from the lowest: compound 1; then compound 3; then compound 2.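

In this assay, replacing 4-hydroxy-2-methylphenyl with 4-ethylphenyl gives a 4.1-fold lower number from compound 2 to compound 3 (0.61 log units; beyond the scatter), so an aromatic group with no hydroxy and an ethyl chain gives stronger growth inhibition at this carbon than the group in compound 2. The position is also sensitive to a small change in the chain: methyl in place of hydrogen on the saturated chain carbon gives a 3.8-fold higher number from compound 1 to compound 3 (0.58 log units; beyond the scatter), so 4-methylphenyl and 4-ethylphenyl are not interchangeable here, and compound 1 remains the strongest growth inhibitor of the three. No measurement available here explains either step.

The 4-hydroxy-2-methylphenyl group of compound 2 differs from the groups in compound 1 and compound 3 in more than one feature, so these compounds cannot show how much of its weaker inhibition belongs to the hydroxy and how much to the added methyl. On these data alone, it also remains open whether a propyl or longer chain would continue the move to higher numbers seen from methyl to ethyl, and how an amine in place of the hydroxy would compare.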